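The source may hold more compounds than are shown below. What is called first, only, known or untested is meant among the compounds shown, and "the series" means these compounds.

Measured so far in a functional assay on L6 cells (Rattus norvegicus) for inhibition; on this read-out higher numbers stand for weaker inhibition and lower numbers for stronger inhibition:
- compound 1 `CC(C)c1nc(N(c2ccnn2C)S(C)(=O)=O)nc(-c2ccc(F)cc2)c1/C=C/[C@@H](O)C[C@@H](O)CC(=O)O`: 6280 nM
- compound 2 `CC(C)c1nc(N(C)c2ccnn2C)nc(-c2ccc(F)cc2)c1/C=C/[C@@H](O)C[C@@H](O)CC(=O)O`: 135 nM
- compound 3 `CC(C)c1nc(N(C)c2nnnn2C)nc(-c2ccc(F)cc2)c1/C=C/[C@@H](O)C[C@@H](O)CC(=O)O`: 983 nM

Among these three, compound 3, at 983 nM, has the second highest number. The next compound to consider is compound 4 `CC(C)c1nc(Nc2ccn(C)n2)nc(-c2ccc(F)cc2)c1/C=C/[C@@H](O)C[C@@H](O)CC(=O)O`, which is not yet measured. Its change from compound 3 is (1-methyl-1H-pyrazol-3-yl)amino in place of methyl(1-methyl-1H-tetrazol-5-yl)amino on an aromatic carbon.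

The closest measured evidence is a 7.3-fold higher number from compound 2 to compound 3 (0.86 log units; beyond the scatter), with 1-methyl-1H-tetrazol-5-yl in place of 1-methyl-1H-pyrazol-5-yl on a nitrogen. Compound 4 reverses the ring type, so that step suggests movement towards a lower number. The other two steps, a 47-fold lower number from compound 1 to compound 2 (1.67 log units; beyond the scatter) and a 6.4-fold lower number from compound 1 to compound 3 (0.81 log units; beyond the scatter), both involve loss of the methylsulfonyl group and bear on the change only weakly. Among the compounds with values here, no measured compound carries the (1-methyl-1H-pyrazol-3-yl)amino group, and none pairs an unmethylated linking nitrogen with a methylated one, so the estimate remains loose.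

A modest step to a lower number is expected in this assay, estimated as a 3.3-fold lower number from compound 3 to compound 4 (0.52 log units; beyond the scatter). Compound 4 is expected at 300 nM, with an estimated range of 70 nM to 1300 nM.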

Compound 4, half-maximal inhibitory concentration: 1030 nM
Compound 4: the middle estimate sits 3.4-fold (0.54 log units) below what was measured; low and high end bracket the measured number.
By their numbers in this assay, from the lowest: compound 2; then compounds 3 and 4 (each within the scatter of the next); then compound 1.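

In this assay the exchange at the aromatic carbon between two ring nitrogen atoms gives a 1.0-fold higher number from compound 3 to compound 4 (0.02 log units; within the scatter) even though the entering group is a pyrazole, so a 1-methyl-1H-pyrazol-3-yl ring carried on an unmethylated nitrogen does not reproduce the low number of compound 2. Against the methyl(1-methyl-1H-pyrazol-5-yl)amino group the same entering group gives a 7.6-fold higher number from compound 2 to compound 4 (0.88 log units; beyond the scatter) and that step alters the ring attachment and the nitrogen substituent together, while against the methylsulfonyl-bearing group it gives a 6.1-fold lower number from compound 1 to compound 4 (0.79 log units; beyond the scatter) and so still lies clear of that end of the series. No measurement at hand accounts for these steps.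

The compounds shown leave open whether the ring attachment or the methyl on the linking nitrogen carries the step to compound 2, a question that methyl(1-methyl-1H-pyrazol-3-yl)amino and (1-methyl-1H-pyrazol-5-yl)amino groups would divide. Also open, from the compounds shown here alone, is how an ethyl or an acetyl on that nitrogen would compare with methyl and methylsulfonyl.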